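This account rests on a few compounds, and the source may have more. Where it says the series, first, only, none or still open, it means among the compounds named here.

Compound 2 `CC(C)Oc1ccc(-c2cc(C(=O)O)nn2-c2ccccc2)cc1` carries an isopropoxy group on the shared core of this small series. Among the measured compounds shown here, in an assay for displacement of a labelled ligand from Apoptosis regulator Bcl-2 (Homo sapiens), read by fluorescence polarization, with a stated time of 30 min (a lower number here means a stronger inhibitor, a higher number a weaker inhibitor), compound 2 gives 7000 nM, the larger of the two numbers measured so far, although the gap to its only neighbour is within the scatter: compound 1 `CCOc1ccc(-c2cc(C(=O)O)nn2-c2ccccc2)cc1` gives 6090 nM in this assay. The unmeasured compound 3 `CC(C)COc1ccc(-c2cc(C(=O)O)nn2-c2ccccc2)cc1` differs from compound 2 by isobutyl in place of isopropyl on an oxygen on an aromatic ring. For the measured compounds named here, the one measured step that bears on this change is a 1.1-fold higher number from compound 1 to compound 2 (0.06 log units; within the scatter), a lengthening of the same kind at the same oxygen, and it moved the number hardly at all. Extending the chain once more at that place is therefore expected to give no step beyond the scatter, in either direction. Compound 3 is estimated at 7000 nM, with a range from 3000 nM to 16000 nM. The expected step is no change at the digits printed from compound 2 to compound 3 (within the scatter).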

Compound 3, inhibition constant: > 10000 nM
Compound 3: a limit, no number (the forecaster's own chance of this, stated with the estimate: 5%); at least 1.4-fold (0.15 log units) between middle value and limit.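

Compound 3 is recorded in this assay as a limit and not a number: the limit of > 10000 nM in this assay, at which 1 of the 3 values shown sits. On this oxygen, the change from isopropyl to isobutyl can therefore be read only as a floor, an at least 1.4-fold higher number from compound 2 to compound 3 (0.15 log units; that floor lies within the scatter), and the wider change gives another floor, an at least 1.6-fold higher number from compound 1 to compound 3 (0.21 log units; that floor lies within the scatter). Among the compounds shown here, the earlier step stayed within the scatter, and compound 3 is the first of the series without a number, but neither floor shows a step beyond the scatter.

As far as these compounds go, how far compound 3 actually lies from compound 1 and compound 2 remains open. So does whether a longer chain, or an amine at the end of the chain on this oxygen, would give a number in this assay at all.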